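Notes on the amine substituent swap at the ring nitrogen

This account rests on a few compounds, and the source may have more. Where it says the series, first, only, none or still open, it means among the compounds named here.

Compound 1 `Clc1cc(Cl)cc(CO[C@H]2CCCN(Cc3ncc[nH]3)[C@H]2c2ccccc2)c1` gives 47000 nM in an assay on isolated protein for activation of cGMP-dependent protein kinase 1 (Homo sapiens), read by ADP-Glo, with stated times of 120 min and 40 min; a higher number here means that more compound is needed for the effect, a lower number that less compound is needed. Compound 2 `O=C(O)c1ccc(CN2CCC[C@H](OCc3cc(Cl)cc(Cl)c3)[C@@H]2c2ccccc2)cn1` reaches only the assay limit of > 200000 nM in this assay, so no number is known for it. Its position is the limit of > 200000 nM in this assay, at which 1 of the 2 values shown sits. Compound 3 `Cn1ccnc1CN1CCC[C@H](OCc2cc(Cl)cc(Cl)c2)[C@@H]1c1ccccc1` differs from compound 2 by 1-methyl-1H-imidazol-2-yl in place of 6-carboxypyridin-3-yl on a saturated chain carbon bound to an amine nitrogen in a ring. Among the measured compounds shown here, the one measured step at this position, an at least 4.2-fold higher number from compound 1 to compound 2 (0.62 log units; beyond the scatter), ran the opposite way when 1H-imidazol-2-yl gave way to 6-carboxypyridin-3-yl, so a return toward a lower number is expected for compound 3. Compound 3 is estimated at 60000 nM, within 20000 nM to 200000 nM. The expected step is an at least 3.3-fold lower number from compound 2 to compound 3 (0.52 log units; beyond the scatter).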

Compound 3, half-maximal effective concentration: 165000 nM
For compound 3 the middle estimate is 2.8-fold (0.44 log units) below the measured one, and the stated range covers the measured number.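

In this assay, methyl in place of hydrogen on an aromatic nitrogen gives a 3.5-fold higher number from compound 1 to compound 3 (0.55 log units; beyond the scatter), so this position responds to that single change, and the response is toward more compound needed. Replacing 6-carboxypyridin-3-yl with 1-methyl-1H-imidazol-2-yl gives an at least 1.2-fold lower number from compound 2 to compound 3 (0.08 log units; that floor lies within the scatter), which leaves the size of this change unsettled. Compound 2 is held at a limit and not at a number: the limit of > 200000 nM in this assay, at which 1 of the 3 values shown sits.

Open, from the compounds shown here alone, is whether ethyl on the same aromatic nitrogen would move the number further than methyl. Also open, going by these compounds, is how a primary amine on the imidazole ring would compare.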